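Adding a Methyl to the Side Chain of Compound 3

A few compounds are considered here, and "the series" means these few. Any claim that something is new, unique, unknown or untested is made for them only; others in the source may bear on it.

Compound 1 `CCNc1ncnc2c1ncn2CC1CC1` gives 22 mg/kg in a functional assay on the whole organism for antagonist activity, with Rattus norvegicus as the target; on this read-out lower numbers stand for an effect already at smaller amounts and higher numbers for an effect only at larger amounts of compound.
Compound 2 `CC(C1CC1)n1cnc2c(NC3CC3)ncnc21` gives 2 mg/kg; 4.5 mg/kg; 12.5 mg/kg (3 entries).
Compound 3 `O=CN(c1ncnc2c1ncn2CC1CC1)C1CC1` gives 8 mg/kg.

Of the two compounds with a single number in this assay, compound 3 holds the lower one, and the step of a 2.8-fold lower number from compound 1 to compound 3 (0.44 log units; beyond the scatter) lies beyond the scatter. Compound 2 has several entries the several entries of compound 2 in this assay, 2 mg/kg; 4.5 mg/kg; 12.5 mg/kg (3 entries) rather than one number. Compound 4 `CC(C1CC1)n1cnc2c(N(C=O)C3CC3)ncnc21` differs from compound 3 only by methyl in place of hydrogen on a saturated chain carbon bound to an aromatic nitrogen and a saturated ring carbon. For the measured compounds named here, no measured step covers this change; the only measured step, a 2.8-fold lower number from compound 1 to compound 3 (0.44 log units; beyond the scatter), concerns a different group. Compound 2, which carries the 1-cyclopropylethyl, gives numbers overlapping those of compound 3, so a step within the scatter or at most a modest lowering is expected, a 1.6-fold lower number from compound 3 to compound 4 (0.20 log units; within the scatter). Compound 4 is therefore estimated at 5 mg/kg, with a range from 1.5 mg/kg to 15 mg/kg.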

Compound 4, dose for half-maximal effect: 2.5 mg/kg
Compound 4: the middle estimate sits 2.0-fold (0.30 log units) above what was measured; low and high end bracket the measured number.
By their numbers in this assay, from the lowest: compound 4; then compound 3; then compound 1.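

The side chain turns out to be a place where a small change counts: going from cyclopropylmethyl to 1-cyclopropylethyl gives a 3.2-fold lower number from compound 3 to compound 4 (0.51 log units; beyond the scatter) in this assay. For the compounds shown here, the only earlier step concerned a different group, so this is the first measured sign that a single added methyl on this carbon brings the effect to smaller amounts.

From the compounds shown here alone, whether a longer chain, such as propyl, or a hydroxymethyl on the same carbon would go further remains open. The role of the formyl group also stays unsettled, since compound 2, which lacks it, offers no single number: the several entries of compound 2 in this assay, 2 mg/kg; 4.5 mg/kg; 12.5 mg/kg (3 entries)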